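Replacing a dihydroxyphenyl by a quinone on a pyrazole core

A few compounds are considered here, and "the series" means these few. Any claim that something is new, unique, unknown or untested is made for them only; others in the source may bear on it.

Measured compounds:
- compound 1, `NS(=O)(=O)c1ccc(-n2nc(-c3ccc(Cl)cc3)cc2-c2cc(O)ccc2O)cc1`: 13400 nM
- compound 2, `CC(=O)NS(=O)(=O)c1ccc(-n2nc(-c3ccccc3)cc2-c2cc(O)ccc2O)cc1`: 100000 nM
- compound 3, `NS(=O)(=O)c1ccc(-n2nc(-c3ccc(Cl)cc3)cc2C2=CC(=O)C=CC2=O)cc1`: 21600 nM

All three were tested in a functional assay on cells (Cancer cell lines, Homo sapiens) for cytotoxicity, read by sulforhodamine B assay, with a stated time of 48 h; on this read-out higher numbers stand for weaker inhibition of growth and lower numbers for stronger inhibition of growth. In this assay compound 2 gives the highest of the three numbers, and its gaps to compound 1 and compound 3 are both beyond the usual scatter, so it is the weakest growth inhibitor of the set. The difference between the core of compound 1 and the core of compound 2 is not broken down here.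

Compound 1 and compound 3 differ in one place: a group of 8 heavy atoms (6 carbon, 2 oxygen; one six-membered non-aromatic ring of carbon only) in place of a group of 8 heavy atoms (6 carbon, 2 oxygen; one six-membered aromatic ring of carbon only), on an aromatic carbon This change gave a 1.6-fold higher number from compound 1 to compound 3 (0.21 log units; within the scatter), so swapping the 2,5-dihydroxyphenyl for the non-aromatic ring carrying two carbonyls made no clear difference on the core of compound 1.

Compound 4, `CC(=O)NS(=O)(=O)c1ccc(-n2nc(-c3ccccc3)cc2C2=CC(=O)C=CC2=O)cc1`, is not yet measured. It differs from compound 2 by a group of 8 heavy atoms (6 carbon, 2 oxygen; one six-membered non-aromatic ring of carbon only) in place of a group of 8 heavy atoms (6 carbon, 2 oxygen; one six-membered aromatic ring of carbon only), on an aromatic carbon This is the same kind of change as that from compound 1 to compound 3, but the surroundings are not identical: in compound 2 the place lies next to the ring atom that bears a large group and two ring bonds from the ring atom that bears a phenyl group, whereas in compound 1 it lies next to the ring atom that bears a 4-sulfamoylphenyl group and two ring bonds from the ring atom that bears a 4-chlorophenyl group.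

Because compound 1 to compound 3 gave a 1.6-fold higher number from compound 1 to compound 3 (0.21 log units; within the scatter), the expected step from compound 2 to compound 4 is also small, no change at the digits printed from compound 2 to compound 4 (within the scatter). Compound 4 is therefore estimated at 100000 nM in this assay, with a likely range from 40000 nM to 250000 nM.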

Compound 4, concentration for 50% growth inhibition: 100000 nM
Beside the measured number, compound 4's estimate shows no gap at the digits printed; the range from low to high includes it.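

On the core of compound 2, putting the non-aromatic ring with its two carbonyls in place of the 2,5-dihydroxyphenyl gave, in this assay, no change at the digits printed from compound 2 to compound 4 (within the scatter). Set side by side, the two steps agree, so in this small series the change carries from one core to the other as a step too small to read: the same change on two cores in this assay, a 1.6-fold higher number (0.21 log units; within the scatter) from compound 1 to compound 3 and no change at the digits printed (within the scatter) from compound 2 to compound 4, 1.6-fold (0.21 log units) apart, within the scatter of two such steps

Going by these compounds alone, this agreement rests on only two cores, which differ from each other in more than one place, so it shows no general rule for the swap on other cores, and it does not show that the two groups act in the same way inside cells, only that this read-out does not separate them on either core.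

The compounds shown leave open how other groups would fare in the same place on the five-membered ring, for instance a phenyl ring carrying two methoxy groups, or a plain phenyl without any hydroxyl. Within the data shown here, they also leave open what the 4-chlorophenyl and the acetyl on the sulfonamide nitrogen each contribute alone, as no pair here changes just one of them.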